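This account rests on a few compounds, and the source may have more. Where it says the series, first, only, none or still open, it means among the compounds named here.

In an ADME assay on HEK-293T cells (Homo sapiens) for cytotoxicity, read by luminescence and CellTiter-Glo, with a stated time of 24 h (on this read-out higher numbers stand for lower toxicity in this test and lower numbers for higher toxicity in this test), compound 1 `CCCNC(=O)[C@H]1CC[C@@H](NC(=O)c2cc3sc(Br)cc3n2Cc2ccc(OC)cc2)CC1` gives > 100000 nM, which is a limit of the assay and not a number. Compound 2 `CCCNC(=O)C1CCN(C(=O)c2cc3sccc3n2Cc2ccc(OC)cc2)CC1` gives a measured 18800 nM in this assay. Going by the values given here, compound 1 is the one whose value stands at a limit: the limit of > 100000 nM in this assay, at which 1 of the 2 values shown sits.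

Compound 3 `CCCNC(=O)[C@H]1CC[C@H](NC(=O)c2cc3sc(Br)cc3n2Cc2ccc(OC)cc2)CC1` is the next entry. It has the same atoms and bonds as compound 1 and differs only in configuration as drawn: the two compounds have the same atoms and bonds and differ only in configuration as drawn: 2 of 2 stereo elements differ (all stereocentres are inverted: mirror images); a stereocentre at a saturated ring carbon is drawn s in compound 1 and r in compound 3; a stereocentre at a saturated ring carbon is drawn s in compound 1 and r in compound 3. Among the compounds with values here, no measured pair isolates configuration, so the expectation rests on the limit of compound 1, > 100000 nM. The expected at least 1.1-fold lower number from compound 1 to compound 3 (0.04 log units; that floor lies within the scatter) in this assay is none beyond the scatter, with any real shift more likely toward lower numbers, since the limit leaves room only in that direction. For compound 3 the estimated value is 90000 nM, with an expected range from 30000 nM to 100000 nM.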

Compound 3, half-maximal cytotoxic concentration: > 100000 nM
Compound 3 ended at the assay's limit (the forecaster's own chance of this, stated with the estimate: 60%); middle value at least 1.1-fold (0.04 log units) away from the limit.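

Compound 3 gives > 100000 nM, a limit of the assay and not a number. Going by these compounds alone, compound 1 gives > 100000 nM, also a limit, so no step between compound 1 and compound 3 can be read. From the compounds shown here alone, whether configuration as drawn changes this read-out at all remains open.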